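Compound 3: 4-methylphenyl to 4-fluorophenyl

The source may hold more compounds than are shown below. What is called first, only, known or untested is meant among the compounds shown, and "the series" means these compounds.

In a functional assay on HCT-116 cells (Homo sapiens) for antiproliferative activity, read by MTT assay, with a stated time of 72 h (on this read-out lower numbers stand for stronger inhibition and higher numbers for weaker inhibition), compound 1 `COc1ccc(N2C(=O)COc3ccc(-c4cccc(NS(=O)(=O)c5ccc(F)cc5)c4)cc32)cc1` gives 28300 nM and compound 2 `Cc1ccc(N2C(=O)COc3ccc(-c4cccc(NS(=O)(=O)c5ccc(F)cc5)c4)cc32)cc1` gives 35600 nM. Compound 2 therefore stands within the scatter of compound 1. Compound 3 `O=C1COc2ccc(-c3cccc(NS(=O)(=O)c4ccc(F)cc4)c3)cc2N1c1ccc(F)cc1` differs from compound 2 by one change: fluoro in place of methyl on an aromatic carbon. Among the compounds with values here, the only measured step at that place, methyl in place of methoxy, is small: a 1.3-fold higher number from compound 1 to compound 2 (0.10 log units; within the scatter). No change beyond the scatter is therefore expected, and the estimated step is a 1.2-fold lower number from compound 2 to compound 3 (0.07 log units; within the scatter). For compound 3 the expected value is 30000 nM, with an estimated range of 14000 nM to 65000 nM.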

Compound 3, half-maximal inhibitory concentration: > 40000 nM
Compound 3: only a limit was reported (the forecaster's own chance of this, stated with the estimate: 10%); middle value at least 1.3-fold (0.12 log units) away from the limit.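

In this assay compound 3 gives > 40000 nM, which is a limit and not a number. The steps read as floors only, an at least 1.1-fold higher number from compound 2 to compound 3 (0.05 log units; that floor lies within the scatter) and an at least 1.4-fold higher number from compound 1 to compound 3 (0.15 log units; that floor lies within the scatter), so the true steps may be larger. Fluoro at this place, para to a large group, therefore shows no gain in inhibition over methyl or methoxy, and the series gains its first limit here.

On these data alone, how far compound 3 lies past its limit stays open. So does whether an amine or a carboxylic acid at this place would move the value beyond the scatter.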